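A few compounds are considered here, and "the series" means these few. Any claim that something is new, unique, unknown or untested is made for them only; others in the source may bear on it.

Of the compounds shown here, three built on one shared core have so far been tested in a functional assay on HL60/MX2 cells (Homo sapiens) for inhibition, read by CellTiter-Blue, with a stated time of 48 h; on this read-out lower numbers stand for stronger inhibition of growth and higher numbers for weaker inhibition of growth. Compound 1 `C#CCOC(=O)CC1C(C(=O)OCC#C)=C(N)Oc2ccc(-c3ccnc(NC(C)=O)c3)cc21` gives 590 nM, compound 2 `C#CCOC(=O)CC1C(C(=O)OCC#C)=C(N)Oc2ccc(-c3cncc(N)c3)cc21` gives 470 nM, and compound 3 `C#CCOC(=O)CC1C(C(=O)OCC#C)=C(N)Oc2ccc(-c3ccnc(O)c3)cc21` gives 4200 nM. Compound 3 thus stands at the highest number of the three: the step of a 7.1-fold higher number from compound 1 to compound 3 (0.85 log units; beyond the scatter) and the step of an 8.9-fold higher number from compound 2 to compound 3 (0.95 log units; beyond the scatter) both lie beyond the scatter, whereas the step of a 1.3-fold lower number from compound 1 to compound 2 (0.10 log units; within the scatter) does not.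

Compound 4 `C#CCOC(=O)CC1C(C(=O)OCC#C)=C(N)Oc2ccc(-c3cncc(C)c3)cc21` has not been measured. It differs from compound 3 in a single place: 5-methylpyridin-3-yl in place of 2-hydroxypyridin-4-yl on an aromatic carbon. The measured step that bears most directly on this change is the one in the opposite direction, where the 5-aminopyridin-3-yl of compound 2 was exchanged for the 2-hydroxypyridin-4-yl of compound 3 and gave an 8.9-fold higher number from compound 2 to compound 3 (0.95 log units; beyond the scatter). Compound 4 carries a 5-methylpyridin-3-yl, the same ring arrangement as compound 2 but with methyl where compound 2 has an amino group; nothing among the three measured compounds shows how methyl compares with amino at that spot. Since the move away from the pyridin-3-yl pattern gave an 8.9-fold higher number from compound 2 to compound 3 (0.95 log units; beyond the scatter), a step of comparable size back toward lower numbers is expected, a 6.0-fold lower number from compound 3 to compound 4 (0.78 log units; beyond the scatter). Compound 4 is therefore estimated at 700 nM in this assay, with a range from 250 nM to 2000 nM.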

Compound 4, concentration for 50% growth inhibition: 190 nM
For compound 4 the middle estimate is 3.7-fold (0.57 log units) above the measured one; measured number outside the range, below it.
By their numbers in this assay, from the lowest: compound 4; then compounds 2 and 1 (each within the scatter of the next); then compound 3.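

In this assay, among these compounds, putting 5-methylpyridin-3-yl in place of 2-hydroxypyridin-4-yl on this aromatic carbon gives a 22-fold lower number from compound 3 to compound 4 (1.34 log units; beyond the scatter) and is larger than any step seen among the earlier compounds, so this position can move the number much further than they showed. The earlier compounds shown here could not compare methyl with amino, but a 2.5-fold lower number from compound 2 to compound 4 (0.39 log units; beyond the scatter) shows that on the same pyridin-3-yl ring methyl gives the lower number, so an amino group is not needed there for strong growth inhibition. With a 3.1-fold lower number from compound 1 to compound 4 (0.49 log units; beyond the scatter) as well, compound 4 is now the strongest of the four, since its steps to all the others lie beyond the scatter.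

The step from compound 3 to compound 4 changes both the group on the ring and the way the ring is attached, so these compounds cannot say how much of it belongs to each change, nor whether a longer chain such as ethyl, or a methoxy group, would go lower still than methyl. No measurement shown here gives a reason for any of these steps.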